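Swapping an Ethoxy for a Trifluoromethylsulfonyl Group

A few compounds are considered here, and "the series" means these few. Any claim that something is new, unique, unknown or untested is made for them only; others in the source may bear on it.

For the measured compounds named here, compound 3 `CCOc1cccc(S(=O)(=O)Nc2ccc(N3CCN(c4cccc(-c5c(C(=O)NCCCN6CCN(C)CC6)c(C)n(C)c5-c5ccc(Cl)cc5)c4)CC3)cc2)c1` gives 420 nM in an assay for binding affinity to Apoptosis regulator Bcl-2 (Homo sapiens), read by fluorescence polarization, with a stated time of 2 h (on this read-out lower numbers stand for stronger inhibition and higher numbers for weaker inhibition), the second highest of three numbers measured so far. Its nearest neighbour is compound 1 `Cc1c(C(=O)NCCCN2CCN(C)CC2)c(-c2cccc(N3CCN(c4ccc(NS(=O)(=O)c5cccc(OC(C)C)c5)cc4)CC3)c2)c(-c2ccc(Cl)cc2)n1C`, which gives 522 nM, within the scatter of compound 3; furthest away lies compound 2 `Cc1c(C(=O)NCCCN2CCN(C)CC2)c(-c2cccc(N3CCN(c4ccc(NS(=O)(=O)c5cccc(OC(F)(F)F)c5)cc4)CC3)c2)c(-c2ccc(Cl)cc2)n1C`, which gives 197 nM. Compound 4 `Cc1c(C(=O)NCCCN2CCN(C)CC2)c(-c2cccc(N3CCN(c4ccc(NS(=O)(=O)c5cccc(S(=O)(=O)C(F)(F)F)c5)cc4)CC3)c2)c(-c2ccc(Cl)cc2)n1C` differs from compound 3 by (trifluoromethyl)sulfonyl in place of ethoxy on an aromatic carbon, on an aromatic carbon of a six-membered aromatic ring of carbon only, meta to a large group. Going by the values given here, two measured steps bear on this: a 2.6-fold lower number from compound 1 to compound 2 (0.42 log units; beyond the scatter) and a 2.1-fold higher number from compound 2 to compound 3 (0.33 log units; beyond the scatter), each modest, each placing the trifluoromethyl-bearing compound lower. A similar modest lowering is expected for compound 4, a 2.1-fold lower number from compound 3 to compound 4 (0.32 log units; beyond the scatter), although the entering group is not the same as trifluoromethyl. For compound 4 the estimate in this assay is 200 nM, ranging from 80 nM to 500 nM.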

Compound 4, inhibition constant: 39.2 nM
Beside the measured number, compound 4's estimate is 5.1-fold (0.71 log units) above it, and the stated range ends above it.
By their numbers in this assay, from the lowest: compound 4; then compound 2; then compounds 3 and 1 (each within the scatter of the next).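

In this assay, (trifluoromethyl)sulfonyl on this aromatic carbon gives an 11-fold lower number from compound 3 to compound 4 (1.03 log units; beyond the scatter) against ethoxy and a 13-fold lower number from compound 1 to compound 4 (1.12 log units; beyond the scatter) against isopropoxy. Even against trifluoromethoxy, it gives a 5.0-fold lower number from compound 2 to compound 4 (0.70 log units; beyond the scatter) here, so this place on the ring can shift the number much further than the earlier oxygen-linked groups showed. Nothing available explains this gain.

Going by these compounds, whether the gain needs the sulfonyl link or the trifluoromethyl stays open, and methylsulfonyl would help separate the two. A nitrile or a carboxylic acid on this carbon also remains untested among the compounds shown.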